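Carbonyl-aryl variation in the pyrazolyl enone series

A few compounds are considered here, and "the series" means these few. Any claim that something is new, unique, unknown or untested is made for them only; others in the source may bear on it.

Measured compounds:
compound 1 `COc1cc(-c2cc(/C=C/C(=O)c3ccc(N)cc3)[nH]n2)cc(OC)c1OC` gives -64% in a functional assay on RXF 393 cells (Homo sapiens) for cytotoxicity, read by sulforhodamine B assay, with a stated time of 48 h, tested at 10 uM; a lower number here means a stronger effect, a higher number a weaker effect of the compound at the concentration tested
compound 2 `COc1ccc(-c2cc(/C=C/C(=O)c3ccc(OC)c(OC)c3)[nH]n2)cc1` gives -82% in this assay
compound 3 `COc1cc(-c2cc(/C=C/C(=O)c3ccc(Cl)c(Cl)c3)[nH]n2)cc(OC)c1OC` gives 9% in this assay

Compound 3 stands highest of the three numbers in this assay, that is, the weakest effect shown so far; compound 1 is nearest, and compound 2 lies furthest from it. Among the measured compounds shown here, the one single-place step that has been measured runs from compound 1 to compound 3, where 3,4-dichlorophenyl replaced 4-aminophenyl on the carbonyl carbon: a number 73 percentage points higher from compound 1 to compound 3 (beyond the scatter).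

Compound 4 `COc1ccc(C(=O)/C=C/c2cc(-c3cc(OC)c(OC)c(OC)c3)n[nH]2)cc1` is the next compound to be measured. It differs from compound 3 in one place: 4-methoxyphenyl in place of 3,4-dichlorophenyl on a carbonyl carbon

The step from compound 1 to compound 3 bears directly on this change, since it also exchanges the aryl group on the carbonyl carbon, and it was large. Compound 2 differs from compound 4 in more than one place, but it carries methoxy substitution on the carbonyl-side aryl and gives a strongly negative number. Both observations point towards a large step downward from compound 3 to compound 4 in this assay, back into the range of compounds 1 and 2. Compound 4 is therefore expected to give -50%, within -85% to 5%, which is an expected step of a number 59 percentage points lower from compound 3 to compound 4 (beyond the scatter).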

Compound 4, a percentage reported as activity, at one concentration (the size of the read-out at that concentration, not a potency): -97%
For compound 4 the middle estimate is 47 percentage points above the measured one, outside the stated range (below it).
By their numbers in this assay, from the lowest: compound 4; then compound 2; then compound 1; then compound 3.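

In this assay, the aryl group on the carbonyl carbon now has three members on one shared core, and this position proves highly sensitive to the choice of group: a number 106 percentage points lower from compound 3 to compound 4 (beyond the scatter), with 4-methoxyphenyl in place of 3,4-dichlorophenyl. The new compound also separates the two groups that gave low numbers, since a number 33 percentage points lower from compound 1 to compound 4 (beyond the scatter), so methoxy and amino on that aromatic carbon are not interchangeable, and the order on this core runs from 4-methoxyphenyl through 4-aminophenyl to 3,4-dichlorophenyl. Nothing at hand on these compounds accounts for that order or for the size of either step.

These three groups do not show whether the high number of compound 3 belongs to chlorine itself or to the 3,4-pattern, which a 4-chlorophenyl group at the same place would separate, nor whether a hydroxy or a dimethylamino group on that aromatic carbon would fall with methoxy and amino. Compound 2 differs from compound 4 in more than one place, so the contribution of the other aryl group on the core also remains unresolved.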